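The compounds below may be only part of what the source reports. "The series", "measured", "known", "first", "only" and "open" are said of these compounds alone.

For the measured compounds named here, in a functional assay on the whole organism for inhibition, with Brassica napus as the target, with a stated time of 72 h, tested at 10 mg/L (on this read-out lower numbers stand for less inhibition of growth and higher numbers for more inhibition of growth at the one concentration tested), compound 1 `COc1cc(C)nc2n/c(=N/C(=O)c3c(-c4ccc(Cl)cc4Cl)noc3C)sn12` gives 26.4%, the lowest of the two numbers so far; compound 2 `COc1cc(OC)n2s/c(=N\C(=O)c3c(-c4ccc(Cl)cc4Cl)noc3C)nc2n1` gives 49.3%, and the step of a number 22.9 percentage points higher from compound 1 to compound 2 (beyond the scatter) is the only measured change. Compound 3 `CSc1cc(C)nc2n/c(=N/C(=O)c3c(-c4ccc(Cl)cc4Cl)noc3C)sn12` differs from compound 1 by methylsulfanyl in place of methoxy on an aromatic carbon. Going by the values given here, no measured step swaps methoxy for methylsulfanyl, so the modest methyl-to-methoxy step bears on it only loosely; a small shift in either direction, likely within the scatter, is expected. Compound 3 is estimated at 30%, range 12% to 50%, an expected step of a number 3.6 percentage points higher from compound 1 to compound 3 (within the scatter).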

Compound 3, percent growth inhibition at one concentration: 32.8%
Estimate against measurement, compound 3: 2.8 percentage points below, and the stated range covers the measured number.
By their numbers in this assay, from the lowest: compounds 1 and 3 (each within the scatter of the next); then compound 2.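

In this assay, methylsulfanyl in place of methoxy on this aromatic carbon gives a number 6.4 percentage points higher from compound 1 to compound 3 (within the scatter), so the two groups are not separated here. Only a number 22.9 percentage points higher from compound 1 to compound 2 (beyond the scatter), a change at a different ring carbon, has so far moved the read-out beyond the scatter. No measured evidence on the compounds explains either result.

Open, from the compounds shown here alone, is whether an amine or a longer chain such as butoxy on this carbon would separate from compound 1. Also open, going by these compounds, is whether methylsulfanyl would match methoxy in the setting of compound 2.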